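Working notes: from compound 2 to compound 4

The source may report more compounds than this note shows. Statements on the series, on what has been measured and on what is new or still open speak of the compounds shown alone.

Of the compounds shown here, three on the shared core have been read in a functional assay on cells (Homo sapiens) for antiproliferative activity, read by WST assay, with a stated time of 3 days; on this read-out lower numbers stand for stronger inhibition and higher numbers for weaker inhibition. Compound 1 (`N#Cc1cc(=O)[nH]c(=O)n1[C@@H]1O[C@H](CO)[C@@H](O)[C@H]1O`) gives > 50000 nM, which is a limit and not a number. Compound 3 (`O=c1cc(NO)n([C@@H]2O[C@H](CO)[C@@H](O)[C@H]2O)c(=O)[nH]1`) gives > 50000 nM, which is also a limit. Within the data shown here, compound 2 (`O=c1cc(I)n([C@@H]2O[C@H](CO)[C@@H](O)[C@H]2O)c(=O)[nH]1`) gives 27800 nM, the only actual number in the set, so it is the sole firm reference point.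

Compound 4 (`O=c1[nH]c(=O)n([C@@H]2O[C@H](CO)[C@@H](O)[C@H]2O)c(I)c1Br`) keeps the iodo group of compound 2 and differs in one place: bromo in place of hydrogen on an aromatic carbon. The bromo sits on an aromatic carbon, ortho to the iodo group.

Among the measured compounds shown here, no measured step tests this change. The nearest steps replace the iodo group instead of adding a group: an at least 1.7-fold lower number from compound 1 to compound 2 (0.25 log units; that floor lies within the scatter) and an at least 1.7-fold higher number from compound 2 to compound 3 (0.25 log units; that floor lies within the scatter). Both are only floors, and both lie within the scatter. The remaining comparison is a step that the two limits leave unreadable from compound 1 to compound 3. With the limit of > 50000 nM in this assay, at which 2 of the 3 values shown sit, these steps offer no size to carry over, so no step beyond the scatter is expected in this assay, in either direction.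

The expected step is a 1.1-fold lower number from compound 2 to compound 4 (0.05 log units; within the scatter). For compound 4 the estimate is 25000 nM, with an expected range of 9000 nM to 50000 nM.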

Compound 4, half-maximal inhibitory concentration: > 50000 nM
Compound 4 ended at the assay's limit (the forecaster's own chance of this, stated with the estimate: 35%); at least 2.0-fold (0.30 log units) between middle value and limit.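

In this assay compound 4 gives > 50000 nM, which is a limit of the assay and not a number. The earlier steps shown here only exchanged the group on one aromatic carbon, whereas this one keeps the iodo group and places bromo ortho to it, giving an at least 1.7-fold higher number from compound 2 to compound 4 (0.25 log units; that floor lies within the scatter); that floor lies within the scatter, so no real loss is established, but the added bromo also brings no measurable gain in inhibition at this position. Compound 2 therefore remains the only compound with an actual number, and the size of this step stays tied to a limit: the limit of > 50000 nM in this assay, at which 3 of the 4 values shown sit.

Going by these compounds, whether a different group on this carbon, such as an amine, a carboxylic acid or a longer chain, would give a number rather than a limit remains open. Also open, on these data alone, is what a bromo group does on this carbon with hydrogen in place of the iodo group.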